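The compounds below may be only part of what the source reports. "The series", "measured", "known", "first", "only" and "open" are said of these compounds alone.

Values in a functional assay on CCRF-CEM cells (Homo sapiens) for antiproliferative activity, with a stated time of 72 h; a higher number here means a weaker inhibitor, a lower number a stronger inhibitor:
- compound 1 `OC[C@H]1O[C@@H](n2cnc3c(NCc4cccc(Br)c4)ncnc32)[C@H](O)[C@@H]1O`: 5000 nM
- compound 2 `OC[C@H]1O[C@@H](n2cnc3c(NCc4ccc(F)c(F)c4F)ncnc32)[C@H](O)[C@@H]1O`: 58200 nM
- compound 3 `OC[C@H]1O[C@@H](n2cnc3c(NCc4c(F)ccc(F)c4F)ncnc32)[C@H](O)[C@@H]1O`: 90300 nM
- compound 4 `OC[C@H]1O[C@@H](n2cnc3c(NCc4ccc(F)c(Cl)c4)ncnc32)[C@H](O)[C@@H]1O`: not yet measured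

Compound 3 lies well above the 3-bromophenyl compound and within the scatter of the other trifluorophenyl compound: a 1.6-fold higher number from compound 2 to compound 3 (0.19 log units; within the scatter). The next change is 3-chloro-4-fluorophenyl in place of 2,3,6-trifluorophenyl on a saturated chain carbon bound to a nitrogen on an aromatic ring. The steps bearing on it are a 12-fold higher number from compound 1 to compound 2 (1.07 log units; beyond the scatter) and an 18-fold higher number from compound 1 to compound 3 (1.26 log units; beyond the scatter), both large. The 3-chloro-4-fluorophenyl group is not a trifluorophenyl group and, like 3-bromophenyl, carries a halogen other than fluorine. Among the compounds with values here, no measured compound carries chlorine, so the return is expected to be only partial. A large drop in this assay is expected, the estimated step being a 9.0-fold lower number from compound 3 to compound 4 (0.96 log units; beyond the scatter). For compound 4 the estimate is 10000 nM, with an expected range of 3000 nM to 40000 nM.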

Compound 4, half-maximal inhibitory concentration: 3400 nM
The estimate for compound 4 lay 2.9-fold (0.47 log units) above the measured number; the range from low to high includes it.
By their numbers in this assay, from the lowest: compounds 4 and 1 (each within the scatter of the next); then compounds 2 and 3 (each within the scatter of the next).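

At this place, on a saturated chain carbon bound to a nitrogen on an aromatic ring, the trifluorophenyl groups are not the only halogenated option: in this assay, 3-chloro-4-fluorophenyl gives a 27-fold lower number from compound 3 to compound 4 (1.42 log units; beyond the scatter) and a 17-fold lower number from compound 2 to compound 4 (1.23 log units; beyond the scatter). Against 3-bromophenyl the change gives a 1.5-fold lower number from compound 1 to compound 4 (0.17 log units; within the scatter), so these two groups cannot be told apart here. Nothing available explains these differences.

Which of the two halogens carries the step remains unresolved. An unsubstituted phenyl group, or a methoxy group or an amine on the ring in place of the halogens, would test whether any halogen is needed.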